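Swapping a benzylamino group for 2-fluorophenyl on a triterpenoid

A few compounds are considered here, and "the series" means these few. Any claim that something is new, unique, unknown or untested is made for them only; others in the source may bear on it.

Three compounds have so far been measured in a functional assay on MCF7 cells (Homo sapiens) for antiproliferative activity, read by MTT assay, with a stated time of 72 h; on this read-out lower numbers stand for stronger inhibition and higher numbers for weaker inhibition:

Compound 1, `CC(=O)O[C@H]1CC[C@]2(C)[C@H](CC[C@@](C)(O)[C@H]2CC[C@@H]2C(C)=CC[C@H]3[C@H](CC[C@]3(C)OC(C)=O)C2(C)C)OC1(C)C`, gives 39200 nM.
Compound 2, `CC(=O)O[C@H]1CC[C@]2(C)[C@H](CC[C@@](C)(O)[C@H]2CC[C@@H]2C(C)=CC[C@@H]3C(C)=CC[C@@H]3C2(C)C)OC1(C)C`, gives 43500 nM.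
Compound 3, `CC1=CC[C@H]2[C@H](CC[C@]2(C)O)C(C)(C)[C@@H]1CC[C@H]1[C@]2(C)CC[C@H](OC(=O)NCc3ccccc3)C(C)(C)O[C@H]2CC[C@@]1(C)O`, gives 24500 nM.

Compound 3 shows the lowest of the three numbers, but its gap to compound 1 and to compound 2 is within the scatter of repeated measurements, so the three cannot be ranked against one another; they sit, as far as these numbers tell, at about the same level in this assay.

Compound 4, `CC1=CC[C@H]2[C@H](CC[C@]2(C)O)C(C)(C)[C@@H]1CC[C@H]1[C@]2(C)CC[C@H](OC(=O)c3ccccc3F)C(C)(C)O[C@H]2CC[C@@]1(C)O`, is built from compound 3 by one change: 2-fluorophenyl in place of benzylamino on a carbonyl carbon. Cut one bond further out, the same change reads benzylcarbamoyl to (2-fluorophenyl)carbonyl.

Among the measured compounds shown here, no pair of measured compounds differs in exactly one place, so there is no measured step to lean on. With no guide of that kind, and with all three measured values lying close together, the step of a 1.0-fold higher number from compound 3 to compound 4 (0.01 log units; within the scatter) is expected to be small, without a clear direction, and most likely within the scatter. Compound 4 is therefore expected to give about 25000 nM, with a range from 10000 nM to 60000 nM.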

Compound 4, half-maximal inhibitory concentration: 11300 nM
Compound 4: middle estimate off by 2.2-fold (0.34 log units), on the high side; measured number inside the range.
By their numbers in this assay, from the lowest: compound 4; then compounds 3, 1 and 2 (each within the scatter of the next).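

In this assay, the change of benzylamino to 2-fluorophenyl on a carbonyl carbon gives a 2.2-fold lower number from compound 3 to compound 4 (0.34 log units; beyond the scatter), a modest step but one beyond the scatter. The earlier compounds shown here, with no pair among them differing in one place, gave no sign of whether a single change on the shared core could move this number at all; this position now shows that one can, and the lower number comes with the 2-fluorophenyl group. The change is a bundle, though: the nitrogen and its hydrogen-bond donor leave, a fluorine enters, and the aromatic ring stays. Nothing available here explains the step.

As far as these compounds go, what remains open is which part of this bundle matters: a plain phenyl group on the same carbonyl carbon would separate the loss of the amino nitrogen from the arrival of the fluorine, and a phenylamino or 2-fluorobenzylamino group would test the same question from the other side. From the compounds shown here alone, it is also open whether larger steps lie at this position, for instance with a pyridyl ring or a simple cyclohexyl group in place of the aromatic ring.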